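Lengthening a Chain: What to Expect for Compound 3

The compounds below may be only part of what the source reports. "The series", "measured", "known", "first", "only" and "open" are said of these compounds alone.

Compound 1, `CC1(C)N=C(N)N=C(N)N1c1cccc(OCCOc2ccccc2)c1`, gives 7.34 in a functional assay on L5178Y cells (Mus musculus) for inhibition; a higher number here means a more potent compound, by a factor of ten per unit of this negative logarithm, a lower number a less potent compound.
Compound 2, `CCCCCCCCCOc1cccc(N2C(N)=NC(N)=NC2(C)C)c1`, gives 6.93 in this assay.

Compound 2 stands lowest of the two measured compounds. Among the measured compounds shown here, its nearest neighbour is compound 1, and the one measured step, a number 0.41 log units lower from compound 1 to compound 2 (beyond the scatter), came with heptyl in place of phenoxy on a saturated chain carbon, two bonds along the chain from an oxygen on an aromatic ring.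

Compound 3, `CCCCCCCCCCCCOc1cccc(N2C(N)=NC(N)=NC2(C)C)c1`, is the next compound to be measured in this assay. It differs from compound 2 in one place: propyl in place of hydrogen on a saturated chain carbon, nine bonds along the chain from an oxygen on an aromatic ring.

For the measured compounds named here, no measured step adds carbons at the far end of such a chain, so the only guide is the step from compound 1 to compound 2, which shows that reworking the chain shifted the number modestly and downward. The expected step is therefore small, downward or none beyond the scatter, and is estimated as a number 0.13 log units lower from compound 2 to compound 3 (within the scatter). Compound 3 is expected to give 6.8 in this assay, with a range from 6.3 to 7.3.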

Compound 3, logarithm of the reciprocal of the active concentration, log(1/C): 6.41
For compound 3 the middle estimate is 0.39 log units above the measured one, and the stated range covers the measured number.
By their numbers in this assay, from the lowest: compound 3; then compound 2; then compound 1.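

In this assay, propyl in place of hydrogen on a saturated chain carbon, nine bonds along the chain from an oxygen on an aromatic ring, came with a number 0.52 log units lower from compound 2 to compound 3 (beyond the scatter). This position is therefore not indifferent to added carbons: a change this far along the chain from the oxygen still moves the number beyond the scatter, and here it moves it downward, something the earlier step, which swapped phenoxy for heptyl, could not show. The data give no explanation for this fall, and no other measurement on these compounds bears on it.

A single step of this kind cannot tell whether the number falls a little with each added carbon or drops sharply once the chain passes some length, and a decyl chain, which would fall between compound 2 and compound 3, could help separate those two readings. As far as these compounds go, it also remains open whether a still longer chain would lower the number further, and whether an amine or a carboxylic acid placed on the chain would change the picture.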